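A few compounds are considered here, and "the series" means these few. Any claim that something is new, unique, unknown or untested is made for them only; others in the source may bear on it.

In a functional assay on SiHa cells (Homo sapiens) for inhibition, read by sulforhodamine B assay (on this read-out higher numbers stand for weaker inhibition of growth and lower numbers for stronger inhibition of growth), compound 1 (`Clc1cccc(-c2ccc(-c3ccc(-c4nc5ccccc5[nH]4)cc3)cc2)c1`) gives 100000 nM, the higher of the two numbers available. Among the measured compounds shown here, the only other measured compound, compound 2 (`COc1ccc(-c2ccc(-c3ccc(-c4nc5ccccc5[nH]4)cc3)cc2)cc1OC`), gives 6200 nM. Compound 3 (`Oc1cccc2[nH]c(-c3ccc(-c4ccc(-c5cccc(Cl)c5)cc4)cc3)nc12`) keeps the 3-chlorophenyl group of compound 1 and has not yet been measured. It differs from compound 1 by hydroxy in place of hydrogen on an aromatic carbon, in a six-membered aromatic ring of carbon only that is part of a fused or bridged system of two rings.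

For the measured compounds named here, only one measured step is available, a 16-fold lower number from compound 1 to compound 2 (1.21 log units; beyond the scatter). It is large and beyond the scatter, but it replaces 3-chlorophenyl with 3,4-dimethoxyphenyl, so it changes a different place and bears on compound 3 only indirectly. It does show that one change to compound 1 can lower the number substantially. Going by the values given here, no measured compound carries the new hydroxy, so the size of the step remains uncertain. A moderate move to a lower number is expected, with a wide margin. The estimate corresponds to an expected step of a 10-fold lower number from compound 1 to compound 3 (1.00 log units; beyond the scatter). In this assay, the estimated value for compound 3 is 10000 nM, with an expected range from 1500 nM to 60000 nM.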

Compound 3, concentration for 50% growth inhibition: 8400 nM
Compound 3: middle estimate off by 1.2-fold (0.08 log units), on the high side; measured number inside the range.
By their numbers in this assay, from the lowest: compounds 2 and 3 (each within the scatter of the next); then compound 1.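

In this assay, hydroxy in place of hydrogen on an aromatic carbon of the six-membered aromatic ring of carbon only, part of a fused or bridged system of two rings, gives a 12-fold lower number from compound 1 to compound 3 (1.08 log units; beyond the scatter). Among the compounds shown here, the only earlier step, a 16-fold lower number from compound 1 to compound 2 (1.21 log units; beyond the scatter), came from changing the 3-chlorophenyl group, whereas this one keeps that group and shows that the number also responds to a change at a second place in compound 1, and that a single added hydroxy is enough to produce a large step there. No available evidence accounts for the size of this step, so the result records the change in the number without explaining it.

The compounds shown leave open whether this step belongs to hydroxy specifically or would also appear with another group on the same carbon, such as an amine or a carboxylic acid. They also leave open whether hydroxy would give a similar step on another carbon of that ring, and what would happen if hydroxy and the 3,4-dimethoxyphenyl group were carried together in one compound.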